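Removing a (methylsulfonyl)methyl group: what the partition coefficient may show

This account rests on a few compounds, and the source may have more. Where it says the series, first, only, none or still open, it means among the compounds named here.

Compound 1 `CS(=O)(=O)Cc1cc(C2=CCOCC2)nc(-c2cccc(O)c2)n1` was measured in a physicochemical assay for lipophilicity (a lower number here means a more polar compound, a higher number a more lipophilic compound), where compound 1 gives 3.3. Two further compounds share a different core, whose difference from the core of compound 1 is not broken down here. Compound 2 `CCNC(=O)Nc1ccc(-c2nc(CS(C)(=O)=O)cc([C@]34CCOC[C@H]3C4)n2)cc1` gives 3.6 in this assay, and compound 3 `CCNC(=O)Nc1ccc(-c2nccc([C@]34CCOC[C@H]3C4)n2)cc1` gives 3.9. Compound 1 and compound 2 lie within the scatter of each other, while compound 3 stands beyond the scatter from compound 1.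

Between compound 2 and compound 3 one change is made: hydrogen in place of (methylsulfonyl)methyl on an aromatic carbon. This change produced a number 0.30 log units higher from compound 2 to compound 3 (within the scatter).

Compound 4 `Oc1cccc(-c2nccc(C3=CCOCC3)n2)c1` is not yet measured. It arises from compound 1 by the same kind of change: hydrogen in place of (methylsulfonyl)methyl on an aromatic carbon. The surroundings are not word for word the same, for in compound 1 the site is meta to a 3-hydroxyphenyl group and meta to a group of 6 heavy atoms, whereas in compound 2 it is meta to a group of 7 heavy atoms and meta to a large group.

The step expected is a number 0.30 log units higher from compound 1 to compound 4 (within the scatter), set beside the measured a number 0.30 log units higher from compound 2 to compound 3 (within the scatter). This expectation rests on compound 3, which gives 3.9 after the same kind of change, and on compound 1, which gives 3.3 as the starting point. Compound 4 is therefore estimated at 3.6, with a range from 3.2 to 4.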

Compound 4, partition coefficient: 3.6
The estimate for compound 4 equals the measured number at the digits printed; measured number inside the range.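

In this assay the new step reads a number 0.30 log units higher from compound 1 to compound 4 (within the scatter), and the step already measured on the other core reads a number 0.30 log units higher from compound 2 to compound 3 (within the scatter), so hydrogen in place of (methylsulfonyl)methyl gives a step of the same printed size on both cores. Both steps lie within the scatter, which means the two pairs agree with each other, but neither pair shows on its own that the change moves the number at all, and two pairs on two cores set no rule for the series as a whole. Nothing measured here bears on why the step has this size, or on why it matches across the two cores.

The compounds shown leave open whether a step of this size would also appear with another group on the same aromatic carbon, such as an amine, a carboxylic acid or a longer chain in place of (methylsulfonyl)methyl. They also leave open whether the match between the two pairs would hold on a third core, and whether a step beyond the scatter can be reached at this place by any such replacement.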